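Ester Chain Length and Cytotoxicity in Three Related Esters

The source may hold more compounds than are shown below. What is called first, only, known or untested is meant among the compounds shown, and "the series" means these compounds.

Compound 1, `C=CCCCCCCCCC(=O)O[C@H]1[C@H](O)[C@H](n2ccc(N)nc2=O)O[C@@H]1CO`: 0.05 ug/mL
Compound 2, `CCCCCCCCCCCCCC(=O)O[C@H]1[C@H](O)[C@H](n2ccc(N)nc2=O)O[C@@H]1CO`: 0.08 ug/mL
Compound 3, `CC(=O)O[C@H]1[C@H](O)[C@H](n2ccc(N)nc2=O)O[C@@H]1CO`: 0.14 ug/mL

The three measured compounds share one core and differ only in the acyl group of an ester. In a functional assay on HeLa cells (Homo sapiens) for cytotoxicity, read by cell counting, with a stated time of 48 h (on this read-out higher numbers stand for an effect only at larger amounts of compound and lower numbers for an effect already at smaller amounts), compound 3 gives the highest number of the three. Its gap to compound 2 is within the scatter, so the two values cannot be told apart; its gap to compound 1 is the step of a 2.8-fold higher number from compound 1 to compound 3 (0.45 log units; beyond the scatter), a modest but real difference.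

Compound 4, `CCCCCCCCC(=O)O[C@H]1[C@H](O)[C@H](n2ccc(N)nc2=O)O[C@@H]1CO`, has not been measured. It differs from compound 3 by heptyl in place of hydrogen on a saturated chain carbon bound to a carbonyl carbon. Among the measured compounds shown here, two measured steps bear on this change. The step of a 2.8-fold higher number from compound 1 to compound 3 (0.45 log units; beyond the scatter) shows that removing a long chain from the ester raised the number; adding a chain back should move it the other way. The step of a 1.6-fold higher number from compound 1 to compound 2 (0.20 log units; within the scatter) shows that altering a long chain further out changed little, so the exact length of the added chain is expected to matter less than its presence.

Compound 4 is therefore expected to give 0.06 ug/mL in this assay, with a likely range from 0.03 ug/mL to 0.12 ug/mL. This estimate means an expected step of a 2.3-fold lower number from compound 3 to compound 4 (0.37 log units; beyond the scatter), a lowering of roughly the size seen when the chain was removed.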

Compound 4, concentration for half-maximal effect: 0.05 ug/mL
Compound 4: the middle estimate sits 1.2-fold (0.08 log units) above what was measured; the measured number falls inside the stated range.
By their numbers in this assay, from the lowest: compounds 1, 4, 2 and 3 (each within the scatter of the next, the first and the last beyond it).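

In this assay, putting heptyl where compound 3 has a hydrogen gives a direct step of its own, a 2.8-fold lower number from compound 3 to compound 4 (0.45 log units; beyond the scatter), so at this saturated chain carbon bound to a carbonyl carbon the gap is not tied to the vinyl end of compound 1, although compound 2, with the longest chain, stays within the scatter of compound 3. Among the long chains themselves, the numbers cannot be told apart, with no change at the digits printed from compound 1 to compound 4 (within the scatter) and a 1.6-fold lower number from compound 2 to compound 4 (0.20 log units; within the scatter), so neither the vinyl end nor the extra pentyl length further out shows a measurable effect on this read-out. Nothing measured alongside these numbers indicates what lies behind them.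

The compounds shown leave open how little chain is needed, since nothing stands between the hydrogen of compound 3 and the heptyl of compound 4, and an ethyl or a propyl group at this place could fall on either side. Also open, going by these compounds, is whether a chain ending in an amine or a carboxylic acid would keep the number of compound 4 or return it towards that of compound 3.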